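The compounds below may be only part of what the source reports. "The series", "measured", "known", "first", "only" and "open" are said of these compounds alone.

Working notes on the series.

The two measured compounds share one core; compound 1 `Cc1ccccc1C(=O)N(NC(=O)c1ccccc1)C(C)(C)C` carries a 2-methylphenyl on the carbonyl carbon, compound 2 `Cc1cc(C)cc(C(=O)N(NC(=O)c2ccccc2)C(C)(C)C)c1` a 3,5-dimethylphenyl at the same place. In an assay on cells for agonist activity at ecdysone receptor (Bombyx mori), read by a luciferase reporter, with a stated time of 24 h (a lower number here means that less compound is needed, a higher number that more compound is needed for the effect), compound 1 gives 224 nM, and compound 2 gives 69.2 nM. Among the compounds with values here, the single measured step, a 3.2-fold lower number from compound 1 to compound 2 (0.51 log units; beyond the scatter), shows that the substitution pattern of this aryl group moves the read-out by a modest amount. Within the data shown here, compound 2 therefore holds the lower of the two numbers, the only neighbour being compound 1, which stands higher by that step.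

Compound 3 `CCCCCCC(=O)N(NC(=O)c1ccccc1)C(C)(C)C` is not yet measured. Its change from compound 2 is hexyl in place of 3,5-dimethylphenyl on a carbonyl carbon. Among the measured compounds shown here, no measured step bears directly on this change: the one step in hand only compares two aryl groups with each other, and nothing measured shows what happens when the ring is given up altogether. The change is larger in kind than the one measured, so a step beyond the scatter is expected, towards a higher number, and its size can only be guessed from the sensitivity seen in the step from compound 1 to compound 2.

Compound 3 is estimated at 3000 nM in this assay, with a range from 500 nM to 30000 nM. This estimate means an expected step of a 43-fold higher number from compound 2 to compound 3 (1.64 log units; beyond the scatter) from compound 2 to compound 3.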

Compound 3, half-maximal effective concentration: 7240 nM
Compound 3: the middle estimate sits 2.4-fold (0.38 log units) below what was measured; the range from low to high includes it.
By their numbers in this assay, from the lowest: compound 2; then compound 1; then compound 3.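

In this assay the step of a 100-fold higher number from compound 2 to compound 3 (2.02 log units; beyond the scatter) and the step of a 32-fold higher number from compound 1 to compound 3 (1.51 log units; beyond the scatter) are both large and each exceeds the modest step of a 3.2-fold lower number from compound 1 to compound 2 (0.51 log units; beyond the scatter) in size, so replacing the aryl group on the carbonyl carbon with hexyl moves the read-out much further than changing the aryl group from 2-methylphenyl to 3,5-dimethylphenyl. Among the three compounds shown, the two that carry an aromatic ring at this place hold the lower numbers and the open-chain compound 3 holds the highest, with no compound going against this order. No measurement in hand explains the size of this change.

The compounds shown leave open whether a shorter chain such as propyl, a longer chain such as octyl, or a saturated ring such as cyclohexyl would stand nearer to the aryl compounds or as far from them as hexyl. They also leave open how the number responds when chlorine or methoxy takes the place of the methyl groups on the phenyl ring, or when a carboxylic acid or an amine is carried at the end of the hexyl chain.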